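The source may report more compounds than this note shows. Statements on the series, on what has been measured and on what is new or still open speak of the compounds shown alone.

Three compounds of this series have numbers in an assay on cell membranes for binding affinity to Adrenergic receptor alpha-1 (Rattus norvegicus); a higher number here means a weaker inhibitor, a lower number a stronger inhibitor. Compound 1 `COc1cccc2c1CCCC2CCCNCCOc1ccccn1` gives 83 nM. Compound 2 `COc1cccc(CCCCN2CCN(c3ccccn3)CC2)c1` gives 467 nM. Compound 3 `COc1cccc(C2=CCC(N3CCN(c4ccccc4OC)CC3)CC2)c1` gives 408 nM, the second highest of the three: its distance to compound 2 is within the scatter, while its number stands higher than that of compound 1 by more than the scatter. Compound 4 `COc1cccc(C2=CCC(N3CCN(c4cccc5ccccc45)CC3)CC2)c1` has not yet been measured in this assay. It differs from compound 3 in one place: naphthalen-1-yl in place of 2-methoxyphenyl on an amine nitrogen in a ring. Within the data shown here, no measured pair carries this exchange, so nothing here tells the size or direction of the step; a step no larger than the scatter is expected, in either direction. For compound 4 the expected number is 300 nM, within 80 nM to 1200 nM, which means an expected step of a 1.4-fold lower number from compound 3 to compound 4 (0.13 log units; within the scatter).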

Compound 4, inhibition constant: 986 nM
Compound 4: middle estimate off by 3.3-fold (0.52 log units), on the low side; low and high end bracket the measured number.
By their numbers in this assay, from the lowest: compound 1; then compounds 3 and 2 (each within the scatter of the next); then compound 4.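

In this assay, among these compounds, naphthalen-1-yl in place of 2-methoxyphenyl gives a 2.4-fold higher number from compound 3 to compound 4 (0.38 log units; beyond the scatter) and so gives the first reading at this place: the group on the amine nitrogen in the ring changes the number by more than the scatter. The exchange adds a second aromatic ring and removes the single hydrogen-bond acceptor, and this one pair cannot separate those two differences. No evidence on hand explains the step. Open, as far as these compounds go, is how a plain phenyl would stand on the same nitrogen, with neither the methoxy group nor the second ring. A 2-ethoxyphenyl group would test whether a longer chain on the oxygen is tolerated.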